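A side-chain change from compound 3 to compound 4

The source may hold more compounds than are shown below. What is called first, only, known or untested is meant among the compounds shown, and "the series" means these compounds.

Values in a functional assay on MDA-MB-231 cells (Homo sapiens) for cytotoxicity, read by MTT assay, with a stated time of 72 h; a higher number here means a weaker inhibitor, a lower number a stronger inhibitor:
- compound 1 `O=C1c2c[n+]([O-])c3ccccc3c2C(=O)c2c1c1ccccc1n2Cc1cn(C[C@H](O)CO)nn1`: 1310 nM
- compound 2 `O=C1c2c[n+]([O-])c3ccccc3c2C(=O)c2c1c1ccccc1n2Cc1cn(CC(O)CO)nn1`: 1290 nM
- compound 3 `CN1CCN(CCCn2c3c(c4ccccc42)C(=O)c2c[n+]([O-])c4ccccc4c2C3=O)CC1`: 390 nM

The only difference within the first pair is the fact that one of compounds 1 and 2 is drawn with a defined configuration and the other without, at the place where they differ, and the measurements show a 1.0-fold lower number from compound 1 to compound 2 (0.01 log units; within the scatter). In this assay, compound 3 gives the lowest number of the three, at 390 nM, and its steps to both others lie beyond the scatter.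

The next compound is compound 4 `CN(C)CCCCn1c2c(c3ccccc31)C(=O)c1c[n+]([O-])c3ccccc3c1C2=O`. Its structural change is (dimethylamino)methyl in place of 4-methylpiperazin-1-yl on a saturated chain carbon, three bonds along the chain from an aromatic nitrogen. The same difference can be read as 3-(4-methylpiperazin-1-yl)propyl to 4-(dimethylamino)butyl.

The nearest evidence comes from replacing 1-(2,3-dihydroxypropyl)-1H-1,2,3-triazol-4-yl with 2-(4-methylpiperazin-1-yl)ethyl. That exchange gave a 3.4-fold lower number from compound 1 to compound 3 (0.53 log units; beyond the scatter) and a 3.3-fold lower number from compound 2 to compound 3 (0.52 log units; beyond the scatter). Both steps are modest, and both involve a different exchange from the one now in question. Among the compounds with values here, no measured step covers the replacement of 4-methylpiperazin-1-yl by (dimethylamino)methyl, so the evidence for it is only indirect. No step beyond the scatter is therefore expected in this assay, and neither direction is favoured. The expected step is a 1.0-fold higher number from compound 3 to compound 4 (0.01 log units; within the scatter). For compound 4 the estimated value is 400 nM, with an expected range of 150 nM to 1000 nM.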

Compound 4, half-maximal inhibitory concentration: 350 nM
For compound 4 the middle estimate is 1.1-fold (0.06 log units) above the measured one; the range from low to high includes it.
By their numbers in this assay, from the lowest: compounds 4 and 3 (each within the scatter of the next); then compounds 2 and 1 (each within the scatter of the next).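

In this assay, the exchange of 4-methylpiperazin-1-yl for (dimethylamino)methyl on a saturated chain carbon, three bonds along the chain from an aromatic nitrogen, gives a 1.1-fold lower number from compound 3 to compound 4 (0.05 log units; within the scatter) and so shows that, in this pair, the six-membered ring can give way to an open chain with no step beyond the scatter. The open-chain compound also stands apart from the two triazole compounds, with a 3.7-fold lower number from compound 2 to compound 4 (0.57 log units; beyond the scatter) and a 3.7-fold lower number from compound 1 to compound 4 (0.57 log units; beyond the scatter) both modest, so the side chains ending in an amine, in compound 3 and compound 4, now both lie beyond the scatter from the 1-(2,3-dihydroxypropyl)-1H-1,2,3-triazol-4-yl compounds. Nothing measured here speaks to why this exchange leaves the number within the scatter.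

Ring and chain length change together in this one exchange, so the compounds shown cannot separate the loss of the ring from the gain of a chain carbon. Going by these compounds, it also remains open how a morpholine ring, a primary amine, a carboxylic acid or a longer chain at this position would read in this assay.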